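Hydroxy in place of hydrogen on compound 3

A few compounds are considered here, and "the series" means these few. Any claim that something is new, unique, unknown or untested is made for them only; others in the source may bear on it.

Three compounds share one core. Compound 1 `O=C(Cc1cccnc1)c1cc2c(O)cccc2[nH]1` gives 83000 nM in an assay on isolated protein for inhibition of Indoleamine 2,3-dioxygenase 1 (Homo sapiens), read by spectrophotometry; a lower number here means a stronger inhibitor, a higher number a weaker inhibitor. Compound 2 `O=C(Cc1cccnc1)c1cc2ccccc2[nH]1` gives 65000 nM in this assay; the step is a 1.3-fold lower number from compound 1 to compound 2 (0.11 log units; within the scatter). Compound 3 `COc1ccc2[nH]c(C(=O)Cc3cccnc3)cc2c1` gives 49000 nM in this assay; the step is a 1.3-fold lower number from compound 2 to compound 3 (0.12 log units; within the scatter). On the numbers shown compound 3 sits at the low end of the three, with every gap to it within the scatter. Compound 4 `COc1ccc2[nH]c(C(=O)Cc3cccnc3)cc2c1O` carries hydroxy in place of hydrogen on an aromatic carbon. Among the compounds with values here, the only step that bears on this change is the loss of a hydroxy between compound 1 and compound 2, which stayed within the scatter. The expected step of a 1.2-fold higher number from compound 3 to compound 4 (0.09 log units; within the scatter) is therefore none beyond the scatter, if anything toward a higher number. Compound 4 is estimated at 60000 nM, within 25000 nM to 150000 nM.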

Compound 4, half-maximal inhibitory concentration: 63000 nM
Compound 4: middle estimate off by 1.1-fold (0.02 log units), on the low side, within the range that was stated.
By their numbers in this assay, from the lowest: compounds 3, 4, 2 and 1 (each within the scatter of the next).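

Hydroxy in place of hydrogen, ortho to a methoxy group, gives a 1.3-fold higher number from compound 3 to compound 4 (0.11 log units; within the scatter) in this assay and stays within the scatter with methoxy present, matching the step on the core without methoxy: the same change on two cores in this assay, a 1.3-fold lower number (0.11 log units; within the scatter) from compound 1 to compound 2 and a 1.3-fold lower number (0.11 log units; within the scatter) from compound 4 to compound 3, 1.0-fold (0.00 log units) apart, within the scatter of two such steps

Methoxy in place of hydrogen gives a 1.3-fold lower number from compound 1 to compound 4 (0.12 log units; within the scatter) with hydroxy present, matching the step without hydroxy: the same change on two cores in this assay, a 1.3-fold lower number (0.12 log units; within the scatter) from compound 2 to compound 3 and a 1.3-fold lower number (0.12 log units; within the scatter) from compound 1 to compound 4, 1.0-fold (0.00 log units) apart, within the scatter of two such steps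

Across these four compounds, each change reads the same whether or not the other group is present.

Open, from the compounds shown here alone, is whether any group at these places moves the number beyond the scatter. An amine or a carboxylic acid in place of the hydroxy, or a longer chain in place of the methoxy, would address this.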